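Amide variation and cytotoxicity in a shared core

The source may hold more compounds than are shown below. What is called first, only, known or untested is meant among the compounds shown, and "the series" means these compounds.

Measured so far:
compound 1 `N#CC1=C(N)N(c2ccc(S(N)(=O)=O)cc2)C2=C(C(=O)CCC2)C1c1ccc(Cl)cc1Cl`: 50%
compound 2 `N#CC1=C(NC(=O)C2CC2)N(c2ccc(S(N)(=O)=O)cc2)C2=C(C(=O)CCC2)C1c1ccc(Cl)cc1Cl`: 40%
compound 3 `Cc1ccc(C(=O)NC2=C(C#N)C(c3ccc(Cl)cc3Cl)C3=C(CCCC3=O)N2c2ccc(S(N)(=O)=O)cc2)cc1`: 30%

In a functional assay on Ehrlich cells (Mus musculus) for cytotoxicity, read by trypan blue exclusion, with a stated time of 2 h, tested at 25 ug/mL (a lower number here means a weaker effect, a higher number a stronger effect of the compound at the concentration tested), compound 1 gives 50%, compound 2 gives 40% and compound 3 gives 30%. Compound 3 has the lowest of the three numbers; its nearest neighbour is compound 2, within the scatter, while the gap to compound 1 lies beyond it: a number 20 percentage points lower from compound 1 to compound 3 (beyond the scatter), where a (4-methylphenyl)carbonyl replaces hydrogen on an amine nitrogen.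

Compound 4 `N#CC1=C(NC(=O)/C=C/c2ccccc2)N(c2ccc(S(N)(=O)=O)cc2)C2=C(C(=O)CCC2)C1c1ccc(Cl)cc1Cl` differs from compound 3 at the carbonyl carbon: 2-phenylethenyl in place of 4-methylphenyl on a carbonyl carbon. Within the data shown here, the one step that bears on this place, a number 10 percentage points lower from compound 2 to compound 3 (within the scatter), stayed within the scatter, so no change beyond the scatter is expected in this assay, and the step of no change at the digits printed from compound 3 to compound 4 (within the scatter) is estimated accordingly. Compound 4 is therefore expected to give about 30%, between 18% and 45%.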

Compound 4, a percentage reported as activity, at one concentration (the size of the read-out at that concentration, not a potency): 30%
Compound 4: the middle estimate sits on the measured number at the digits printed; measured number inside the range.
By their numbers in this assay, from the lowest: compounds 3, 4, 2 and 1 (each within the scatter of the next, the first and the last beyond it).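

In this assay the change to 2-phenylethenyl on the carbonyl carbon gives no change at the digits printed from compound 3 to compound 4 (within the scatter) and so a double bond outside the aromatic ring shows no effect in this comparison. Set against cyclopropyl, the same group gives a number 10 percentage points lower from compound 2 to compound 4 (within the scatter) and in place of hydrogen on the amine nitrogen its carbonyl form gives a number 20 percentage points lower from compound 1 to compound 4 (beyond the scatter) which makes it the second aromatic amide, after compound 3, to stand beyond the scatter from compound 1. No measured evidence here explains these numbers. From the compounds shown here alone, whether a chain carrying an amine or a carboxylic acid on the carbonyl carbon would shift the read-out remains open.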